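Swapping bromo for methyl on a weak inhibitor

This account rests on a few compounds, and the source may have more. Where it says the series, first, only, none or still open, it means among the compounds named here.

Of the compounds shown here, three sharing one core have been measured so far. In a functional assay on HT-29 cells (Homo sapiens) for inhibition, read by MTT assay, with a stated time of 72 h (a higher number here means a weaker inhibitor, a lower number a stronger inhibitor), compound 1 `CN(C)CCn1c(=O)c(=Cc2ccc(F)cc2F)s/c1=C1\C(=O)Nc2cc(F)ccc21` gives 6460 nM, compound 2 `CCN(CC)CCCn1c(=O)c(=Cc2ccc(O)cc2)s/c1=C1\C(=O)Nc2ccc(C)cc21` gives 770 nM, and compound 3 `CCN(CC)CCCn1c(=O)c(=Cc2ccccc2O)s/c1=C1\C(=O)Nc2ccc(Br)cc21` gives 18100 nM. Compound 3 thus has the highest number of the three and is the weakest inhibitor: its number lies beyond the scatter above that of compound 1, and far above that of compound 2.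

The next compound, compound 4 `CCN(CC)CCCn1c(=O)c(=Cc2ccccc2O)s/c1=C1\C(=O)Nc2ccc(C)cc21`, is not yet measured. It differs from compound 3 in one place: methyl in place of bromo on an aromatic carbon. Compound 2 carries the same methyl at that place and gives the lowest number, though it also differs from compound 4 elsewhere in the structure, so its strong result cannot be credited to the methyl alone.

The expectation for compound 4 is a modest fall in the number, a step from a 3.0-fold lower number from compound 3 to compound 4 (0.48 log units; beyond the scatter) that is estimated to reach just beyond the scatter. Compound 4 is therefore expected to give about 6000 nM in this assay, with a likely range from 1500 nM to 25000 nM.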

Compound 4, half-maximal inhibitory concentration: 8070 nM
Estimate against measurement, compound 4: 1.3-fold (0.13 log units) below; measured number inside the range.
By their numbers in this assay, from the lowest: compound 2; then compounds 1 and 4 (each within the scatter of the next); then compound 3.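

In this assay, among these compounds, methyl in place of bromo on an aromatic carbon gives a 2.2-fold lower number from compound 3 to compound 4 (0.35 log units; beyond the scatter), the first comparison in which only this group changes, and it shows that this position affects the result, though modestly. With that methyl held in place, 2-hydroxyphenyl in place of 4-hydroxyphenyl gives a 10-fold higher number from compound 2 to compound 4 (1.02 log units; beyond the scatter), a much larger step, so the low number of compound 2 goes far more with its 4-hydroxyphenyl group than with its methyl. No measurement here explains either step.

As far as these compounds go, whether chloro, methoxy or an amine at this aromatic carbon would lower the number further remains open. From the compounds shown here alone, it is also open whether swapping bromo for methyl would produce a step of similar size on a compound carrying 4-hydroxyphenyl.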